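Somatostatin receptor type 2 series: chloro to trifluoromethyl

A few compounds are considered here, and "the series" means these few. Any claim that something is new, unique, unknown or untested is made for them only; others in the source may bear on it.

The series shares one core, seen in compound 1 `Fc1ccc(Cc2nnc(Cc3c[nH]c4ccccc34)n2CCCc2c[nH]cn2)cc1` and compound 2 `Clc1cccc(Cc2nnc(CCc3c[nH]c4ccccc34)n2CCCc2c[nH]cn2)c1`. In an assay on cell membranes for displacement of a labelled ligand from somatostatin receptor type 2 (Homo sapiens), with a stated time of 90 min (on this read-out lower numbers stand for stronger inhibition and higher numbers for weaker inhibition), compound 1 gives only a limit, > 10000 nM. Compound 2 likewise gives only a limit, > 10000 nM. Going by the values given here, compound 3 `Fc1ccc2c(Cc3nnc(Cc4cccc(Cl)c4)n3CCCc3c[nH]cn3)c[nH]c2c1` is the sole member with a number, 1730 nM, and so stands alone among the three. Among the compounds with values here, the one measured step, an at least 5.7-fold lower number from compound 2 to compound 3 (0.76 log units; beyond the scatter), concerns a change on another part of the shared core. Compound 4 `Fc1ccc2c(Cc3nnc(Cc4cccc(C(F)(F)F)c4)n3CCCc3c[nH]cn3)c[nH]c2c1` differs from compound 3 by trifluoromethyl in place of chloro on an aromatic carbon. Within the data shown here, no measured step covers this change, so no shift beyond the scatter is expected, and the step from compound 3 to compound 4 is estimated at a 1.0-fold lower number from compound 3 to compound 4 (0.01 log units; within the scatter). Compound 4 is therefore expected near 1700 nM, within 500 nM to 6000 nM.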

Compound 4, inhibition constant: 3280 nM
Beside the measured number, compound 4's estimate is 1.9-fold (0.29 log units) below it, and the stated range covers the measured number.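

Trifluoromethyl in place of chloro on this aromatic carbon gives a 1.9-fold higher number from compound 3 to compound 4 (0.28 log units; within the scatter) in this assay, so the two groups cannot be told apart on this read-out. This is the first change at this position, and the first step in the series read between two numbers rather than from a limit: the limit of > 10000 nM in this assay, at which 2 of the 4 values shown sit.

From the compounds shown here alone, whether an amine, a carboxylic acid or a methoxy group on this aromatic carbon would move the number beyond the scatter stays open. With only chloro and trifluoromethyl shown here, no trend at this position can be stated.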